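The source may report more compounds than this note shows. Statements on the series, on what has been measured and on what is new or still open speak of the compounds shown alone.

Measured so far in a functional assay on cells (Platelet, Homo sapiens) for inhibition (on this read-out higher numbers stand for weaker inhibition and lower numbers for stronger inhibition), on these compounds

- Compound 1 `CCOC(=O)c1ccc(-c2nn(C)c3ccccc23)cc1` gives 270 nM
- Compound 2 `CCOC(=O)c1ccc(-c2nn(Cc3ccccc3Cl)c3ccccc23)cc1` gives 230 nM
- Compound 3 `CCOC(=O)c1ccc(-c2nn(Cc3cccc(OC)c3)c3ccccc23)cc1` gives 260 nM

At 260 nM in this test, compound 3 lies level with the other two, as all three values fall within the usual scatter of one another. Compound 4 `CCOC(=O)c1ccc(-c2nn(Cc3cccnc3)c3ccccc23)cc1` has not yet been measured. The change from compound 3 is pyridin-3-yl in place of 3-methoxyphenyl on a saturated chain carbon bound to an aromatic nitrogen and it places pyridin-3-yl in place of 3-methoxyphenyl on a saturated chain carbon bound to an aromatic nitrogen.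

Three measured steps at this same place bear on the change. Replacing hydrogen with 2-chlorophenyl gave a 1.2-fold lower number from compound 1 to compound 2 (0.07 log units; within the scatter) while replacing hydrogen with 3-methoxyphenyl gave a 1.0-fold lower number from compound 1 to compound 3 (0.02 log units; within the scatter) and replacing 2-chlorophenyl with 3-methoxyphenyl gave a 1.1-fold higher number from compound 2 to compound 3 (0.05 log units; within the scatter) in turn. All three stay within the scatter, so no step beyond the scatter is expected in this assay in either direction. Going by the values given here, no measured compound has a ring with a hetero atom here, so the range stays wide. The expected step is a 1.1-fold higher number from compound 3 to compound 4 (0.03 log units; within the scatter) for now. Compound 4 is estimated at 280 nM with an expected range from 120 nM to 650 nM in this test.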

Compound 4, half-maximal inhibitory concentration: 5550 nM
Compound 4: the middle estimate sits 20-fold (1.30 log units) below what was measured; measured number outside the range, above it.
By their numbers in this assay, from the lowest: compounds 2, 3 and 1 (each within the scatter of the next); then compound 4.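

The earlier compounds shown here made this place, a saturated chain carbon bound to an aromatic nitrogen, look undemanding: hydrogen, 2-chlorophenyl and 3-methoxyphenyl all read alike in this assay, yet pyridin-3-yl gives a 21-fold higher number from compound 3 to compound 4 (1.33 log units; beyond the scatter) and a 24-fold higher number from compound 2 to compound 4 (1.38 log units; beyond the scatter) and, against plain hydrogen, a 21-fold higher number from compound 1 to compound 4 (1.31 log units; beyond the scatter). So having a ring here is not what separates these compounds, as two carbon-only rings sit level with hydrogen, and the one ring with a hetero atom stands far apart from all three. What lies behind this large loss of inhibition cannot be said from the data at hand.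

From the compounds shown here alone, whether the loss goes with the ring nitrogen itself or with where it sits remains open. An unsubstituted phenyl, pyridin-2-yl and pyridin-4-yl at this place would help to separate those possibilities.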